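A few compounds are considered here, and "the series" means these few. Any claim that something is new, unique, unknown or untested is made for them only; others in the source may bear on it.

Measured compounds:
Compound 1, `Cn1ccc(NC(=O)c2cc(F)cc(C#N)c2)n1`: in an in vitro functional assay on HEK293-A cells for antagonist activity at metabotropic glutamate receptor 5 (Rattus norvegicus), read by calcium flux (on this read-out higher numbers stand for weaker inhibition and lower numbers for stronger inhibition), compound 1 gives > 10000 nM, a limit of the assay.
Compound 2, `N#Cc1cc(F)cc(C(=O)Nc2ccon2)c1`: in this assay compound 2 gives > 30000 nM, a limit of the assay.

Compound 2 stands at a limit and not at a number. In this assay compound 2 sits at the limit of > 30000 nM in this assay, at which 1 of the 2 values shown sits. Compound 1 likewise sits at the limit of > 10000 nM in this assay, at which 1 of the 2 values shown sits. Within the data shown here, the single measured step, a step that the two limits leave unreadable from compound 1 to compound 2, joins two limits and therefore cannot be read, so no size and no direction can be taken from it. The unmeasured compound 3, `Cc1cnc(NC(=O)c2cc(F)cc(C#N)c2)s1`, differs from compound 2 in one place: 5-methyl-1,3-thiazol-2-yl in place of 1,2-oxazol-3-yl on an amide-type nitrogen. Among the measured compounds shown here, no measured step bears directly on this exchange, and the one step recorded in this assay gives no guidance on what the change should do. The expectation for compound 3 therefore rests on a wide range rather than on any trend among the measured compounds. Compound 3 is estimated at 2000 nM, between 100 nM and 20000 nM. The step this estimate implies is expected to be an at least 15-fold lower number from compound 2 to compound 3 (1.17 log units; beyond the scatter), and a further limit for compound 3 remains possible.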

Compound 3, half-maximal inhibitory concentration: 863 nM
Beside the measured number, compound 3's estimate is 2.3-fold (0.37 log units) above it; the range from low to high includes it.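

In this assay, among these compounds, compound 3 is the first of the three compounds to give a number and not a limit, so the group on the amide-type nitrogen can decide whether inhibition is read at all on the shared core. Putting 5-methyl-1,3-thiazol-2-yl in place of 1,2-oxazol-3-yl gives an at least 34-fold lower number from compound 2 to compound 3 (1.54 log units; beyond the scatter), and putting it in place of 1-methyl-1H-pyrazol-3-yl gives an at least 11-fold lower number from compound 1 to compound 3 (1.06 log units; beyond the scatter), so the same entering group stands out against both earlier five-membered rings. Among the compounds shown here, both steps start from a limit of the assay and give only a minimum size, and the one step between compound 1 and compound 2 cannot be read.

The compounds shown leave open whether the drop belongs to the 1,3-thiazole ring itself or to its 5-methyl group, and how a 1,3-thiazol-2-yl without the methyl, or with an ethyl or a chlorine in its place, would read in this assay. They also leave open whether a six-membered ring such as pyridin-2-yl on the same amide-type nitrogen would keep the inhibition.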